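A few compounds are considered here, and "the series" means these few. Any claim that something is new, unique, unknown or untested is made for them only; others in the source may bear on it.

Measured so far:
Compound 1 `O=C(Nc1ccc(-c2cscn2)cc1)C1CN(Cc2ccc(F)c(F)c2)C1`: > 20000 nM
Compound 2 `O=C(NC1CCCN(Cc2ccc(F)c(F)c2)C1)c1ccc(-c2cscn2)cc1`: > 20000 nM
Compound 3 `O=C(Nc1ccc(-c2cscn2)cc1)C1CCCN(Cc2cccc(F)c2)C1`: 5000 nM

All three compounds were tested in a functional assay on A-375 cells (Homo sapiens) for activation, with a stated time of 3 days; a higher number here means that more compound is needed for the effect, a lower number that less compound is needed. For compound 1, the entry > 20000 nM is a limit of the assay and not a number. The same holds for compound 2, at > 20000 nM. Among the measured compounds shown here, compound 3, at 5000 nM, therefore stands as the only compound here with an actual number.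

Compound 4 `O=C(Nc1ccc(-c2cscn2)cc1)C1CCCN(Cc2cccc(C(F)(F)F)c2)C1` is compound 3 with one change, trifluoromethyl in place of fluoro on an aromatic carbon, so that 3-fluorophenyl becomes 3-(trifluoromethyl)phenyl. For the measured compounds named here, no measured pair of compounds differs in just one place, so the data offer no direct guide to the size of this step. With compound 3 at 5000 nM as the only anchor, no step beyond the usual scatter in this assay is expected, and no firm direction can be given. The expected change is a 1.3-fold lower number from compound 3 to compound 4 (0.10 log units; within the scatter). The range is kept wide, and a result at the assay limit remains possible. For compound 4 the estimated value is 4000 nM, with an expected range from 1200 nM to 15000 nM.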

Compound 4, half-maximal effective concentration: > 20000 nM
Compound 4: only a limit was reported (the forecaster's own chance of this, stated with the estimate: 15%); middle value at least 5.0-fold (0.69 log units) from the limit.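

Among the compounds shown here, replacing fluoro with trifluoromethyl on an aromatic carbon is the first single change that can be read, and in this assay it gives an at least 4.0-fold higher number from compound 3 to compound 4 (0.60 log units; beyond the scatter). Compound 4 stands at > 20000 nM, which is a limit of the assay and not a number. This shows that the group at this position matters for the result, although the step can be read only as far as the limit allows: the limit of > 20000 nM in this assay, at which 3 of the 4 values shown sit.

The compounds shown leave open whether another group at this position, such as methoxy, an amine or a carboxylic acid, would give a lower number than compound 3 or a result at the limit. They also leave open how the compound with hydrogen in place of fluoro would read, and what causes the step.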